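This account rests on a few compounds, and the source may have more. Where it says the series, first, only, none or still open, it means among the compounds named here.

Compounds measured so far:
- compound 1, `O=C(c1ccccc1)c1cccc(OCC(O)CN2CCC(N3Cc4ccccc4C3=O)CC2)c1`: 960 nM
- compound 2, `O=C1c2ccccc2CN1C1CCN(CC(O)COCc2ccc(C(F)(F)F)cc2)CC1`: 1500 nM

In an assay on isolated protein for inhibition of sodium channel protein type 9 subunit alpha (Mus musculus), read by patch clamp (on this read-out higher numbers stand for weaker inhibition and lower numbers for stronger inhibition), compound 1 gives 960 nM and compound 2 gives 1500 nM; compound 1 shows the lowest of the two numbers, but the gap to compound 2 lies within the scatter of this assay, so the two cannot be told apart. Compound 3, `COc1cccc(OCC(O)CN2CCC(N3Cc4ccccc4C3=O)CC2)c1`, has not been measured. It differs from compound 1 in one place: methoxy in place of benzoyl on an aromatic carbon. Within the data shown here, no measured pair shows this kind of exchange, so there is no step in this assay to lean on. Taking away a group this large for a small one is expected to push the number up, that is towards weaker inhibition, by a moderate step. For compound 3 the expected step from compound 1 is a 2.6-fold higher number from compound 1 to compound 3 (0.42 log units; beyond the scatter). Compound 3 is therefore estimated at 2500 nM, within a range from 900 nM to 8000 nM.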

Compound 3, half-maximal inhibitory concentration: 910 nM
The estimate for compound 3 lay 2.7-fold (0.44 log units) above the measured number; low and high end bracket the measured number.
By their numbers in this assay, from the lowest: compounds 3, 1 and 2 (each within the scatter of the next).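

In this assay, putting methoxy in place of benzoyl on this aromatic carbon, meta to a large group, gives a 1.1-fold lower number from compound 1 to compound 3 (0.02 log units; within the scatter), so compound 1 and compound 3 cannot be told apart. At this position, then, a whole six-membered aromatic ring and a carbonyl can leave with no difference this assay can detect, and a small group without a ring serves as well as a large one with a ring. The two groups each count one hydrogen-bond acceptor, but nothing available explains why the exchange makes no detectable difference.

As far as these compounds go, whether an amine or a carboxylic acid on this same carbon would also leave the number within the scatter remains open. So does whether plain hydrogen there would do the same, or whether methoxy would behave alike on another carbon of the ring.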